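This account rests on a few compounds, and the source may have more. Where it says the series, first, only, none or still open, it means among the compounds named here.

Working notes on the series. The two measured compounds share a core and differ in two places. Compound 1 `CC(C)Oc1ccccc1-c1nc2cc([N+](=O)[O-])ccc2[nH]1` in a functional assay on aorta (Rattus norvegicus, strain Wistar) for inhibition, with a stated time of 60 min (a higher number here means a larger maximal response, a lower number a smaller maximal response), gives 80.7%. Compound 2 `CCOc1ccccc1-c1nc2cc(C(F)(F)F)ccc2[nH]1` in this assay gives 91%, the higher of the two numbers, and the gap to compound 1 lies beyond the scatter.

The next compound, compound 3 `CCOc1ccccc1-c1nc2cc([N+](=O)[O-])ccc2[nH]1`, is not yet measured. Against compound 2 it shows one change, (nitro in place of trifluoromethyl on an aromatic carbon). Compound 1 also carries a nitro group at this position and gives 80.7%, though it differs from compound 3 elsewhere as well, so that value can only orient, not settle, the expectation.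

For compound 3 a small downward step from compound 2 is expected, close to the scatter, with a number 7 percentage points lower from compound 2 to compound 3 (within the scatter) as the estimated size. The maximal response of compound 3 in this assay is estimated at 84%, in a range from 72% to 94%.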

Compound 3, largest response reached (Emax), in percent of the reference or control that the assay uses: 84.8%
Estimate against measurement, compound 3: 0.8 percentage points below, and the stated range covers the measured number.
By their numbers in this assay, from the lowest: compounds 1, 3 and 2 (each within the scatter of the next, the first and the last beyond it).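

In this assay, nitro in place of trifluoromethyl on the aromatic carbon now stands alone as a single change and shows a number 6.2 percentage points lower from compound 2 to compound 3 (within the scatter), so the two groups are not separated at this position. Within the data shown here, the chain on the oxygen can also be read on its own for the first time: hydrogen in place of methyl on the saturated chain carbon shows a number 4.1 percentage points higher from compound 1 to compound 3 (within the scatter). Neither single change leaves the scatter, whereas compound 1 and compound 2, which differ in both places, lie beyond it.

Nothing measured in this series accounts for the size of these steps.

On these data alone, it remains open whether an amine or a carboxylic acid on this aromatic carbon, or a longer chain on the oxygen, would shift the maximal response beyond the scatter.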